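This account rests on a few compounds, and the source may have more. Where it says the series, first, only, none or still open, it means among the compounds named here.

Measured compounds:
Compound 1 `Cc1ccc(/C=C2\CCC/C(=C\c3ccc([N+](=O)[O-])cc3)C2=O)cc1`; in a functional assay on MOLT-4 cells (Homo sapiens) for cytotoxicity, with a stated time of 72 h (on this read-out lower numbers stand for stronger inhibition and higher numbers for weaker inhibition), compound 1 gives 8440 nM.
Compound 2 `O=C1CCCC/C1=C\c1ccccc1[N+](=O)[O-]`; in this assay compound 2 gives 33300 nM.
Compound 3 `COc1ccc(/C=C2\CCC/C(=C\c3ccccc3[N+](=O)[O-])C2=O)cc1`; in this assay compound 3 gives 8900 nM.

Compound 1 has the lowest number of the three. Compound 3 sits within the usual scatter of it, so no order between compound 1 and compound 3 is claimed; compound 2 lies beyond the scatter, with the higher number. Compound 4 `CN(C)c1ccc(/C=C2\CCC/C(=C\c3ccc([N+](=O)[O-])cc3)C2=O)cc1` differs from compound 1 in one place: dimethylamino in place of methyl on an aromatic carbon. Among the compounds with values here, no measured pair shows this change, so its effect is unknown here. With nothing to point either way, the step in this assay is expected to stay within the scatter, carrying a wide range. Compound 4 is expected to give 7000 nM (range 3000 nM to 18000 nM), which means an expected step of a 1.2-fold lower number from compound 1 to compound 4 (0.08 log units; within the scatter).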

Compound 4, half-maximal inhibitory concentration: > 500000 nM
Compound 4: only a limit was reported; the forecaster's own chance of this, stated with the estimate: 5%; middle value at least 71-fold (1.85 log units) from the limit.
By their numbers in this assay, from the lowest: compounds 1 and 3 (each within the scatter of the next); then compound 2. At a limit, above all of these: compound 4.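

In this assay, within the data shown here, replacing 4-methylphenyl with 4-(dimethylamino)phenyl gives the first one-place step: an at least 59-fold higher number from compound 1 to compound 4 (1.77 log units; beyond the scatter). Compound 4 stands at a limit, not a number, so this step has no upper bound: the limit of > 500000 nM in this assay, at which 1 of the 4 values shown sits. The aromatic carbon para to a large group is therefore not indifferent to its substituent, as this single change separates compound 4 from compound 1.

On these data alone, whether a primary amine or an ethyl group at this place would track methyl or dimethylamino remains open.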